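Dropping One Chloro Group: Expected Shift in Cytotoxicity

The compounds below may be only part of what the source reports. "The series", "measured", "known", "first", "only" and "open" are said of these compounds alone.

Compounds measured so far:
compound 1 `Cc1cc(NC(=O)Nc2ccc(Cl)c(Cl)c2)c2ccccc2n1` — 10000 nM
compound 2 `CSc1ccc(NC(=O)Nc2cc(C)nc3ccccc23)cc1` — > 25000 nM (a limit of the assay)
compound 3 `Cc1cc(NC(=O)Nc2ccc(N(C)C)cc2)c2ccccc2n1` — > 25000 nM (a limit of the assay)

Among the compounds with values here, in an ADME assay on Raji cells (Homo sapiens) for cytotoxicity, with a stated time of 72 h (on this read-out lower numbers stand for an effect already at smaller amounts and higher numbers for an effect only at larger amounts of compound), compound 1 gives 10000 nM, the only actual number among the three results. Compound 2 gives no number, only a limit, > 25000 nM. Compound 3 likewise gives only a limit, > 25000 nM. Within the data shown here, the one step between compounds differing in a single place, a step that the two limits leave unreadable from compound 2 to compound 3, cannot be sized, and the remaining values sit at the limit of > 25000 nM in this assay, at which 2 of the 3 values shown sit. Compound 1 therefore stands alone as the sole readable point.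

Compound 4 `Cc1cc(NC(=O)Nc2cccc(Cl)c2)c2ccccc2n1` has not yet been measured. It differs from compound 1 by hydrogen in place of chloro on an aromatic carbon. Among the measured compounds shown here, no measured step concerns a change of this kind; the only measured step is unreadable and involves a different group. The expectation for compound 4 thus rests on compound 1 alone, with the chance that the assay again returns only a limit. Compound 4 is expected to give 18000 nM (between 7000 nM and 40000 nM), so that a 1.8-fold higher number from compound 1 to compound 4 (0.26 log units; within the scatter) is the estimated step, one that need not exceed the scatter.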

Compound 4, half-maximal effective concentration: 18000 nM
Compound 4: middle estimate and measured number agree at the digits printed, within the range that was stated.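

Hydrogen in place of chloro on an aromatic carbon gives the first step in this assay that can be read, a 1.8-fold higher number from compound 1 to compound 4 (0.26 log units; within the scatter). At this place, ortho to a chloro group and para to a large group, the chloro group can therefore leave without a shift beyond the scatter. Compound 4, which keeps one chloro group, still gives a number and not a limit, as compound 1 does.

The compounds shown leave open what happens if the other chloro group also leaves, or if an amine, a carboxylic acid or a longer chain stands at this place instead. The step between the two compounds that give only limits cannot be read, so the groups they carry remain unsized: the limit of > 25000 nM in this assay, at which 2 of the 4 values shown sit.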